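Next step in the series: compound 4

A few compounds are considered here, and "the series" means these few. Any claim that something is new, unique, unknown or untested is made for them only; others in the source may bear on it.

In a functional assay on HCT-116 cells (Homo sapiens) for inhibition, read by MTT assay, with a stated time of 48 h (on this read-out higher numbers stand for weaker inhibition and lower numbers for stronger inhibition), compound 1 `C/C=C/C(=O)N(Cc1ccc(OC)c([N+](=O)[O-])c1)c1cc(OC)c(OC)c(OC)c1` gives 670 nM, compound 2 `C/C=C/C(=O)N(Cc1ccc(OC)c(C)c1)c1cc(OC)c(OC)c(OC)c1` gives 23500 nM and compound 3 `C/C=C/C(=O)N(Cc1cccc(O)c1)c1cc(OC)c(OC)c(OC)c1` gives 6700 nM, which places compound 3 second highest of the three numbers. Compound 4 `C/C=C/C(=O)N(Cc1ccc(OC)c(Cl)c1)c1cc(OC)c(OC)c(OC)c1` is reached by one change: 3-chloro-4-methoxyphenyl in place of 3-hydroxyphenyl on a saturated chain carbon bound to an amide-type nitrogen. Going by the values given here, two measured steps bear on it. Methyl in place of nitro on an aromatic carbon gives a 35-fold higher number from compound 1 to compound 2 (1.54 log units; beyond the scatter), a large step. 3-Hydroxyphenyl in place of 4-methoxy-3-methylphenyl gives a 3.5-fold lower number from compound 2 to compound 3 (0.54 log units; beyond the scatter), a modest one. Among the compounds with values here, no chloro compound has been measured, so a modest step towards a lower number is expected in this assay, with wide uncertainty. The expected change is a 2.4-fold lower number from compound 3 to compound 4 (0.38 log units; beyond the scatter). For compound 4 the estimated value is 2800 nM, with an expected range of 700 nM to 12000 nM.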

Compound 4, half-maximal inhibitory concentration: 1420 nM
Compound 4: the middle estimate sits 2.0-fold (0.29 log units) above what was measured; low and high end bracket the measured number.
By their numbers in this assay, from the lowest: compound 1; then compound 4; then compound 3; then compound 2.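

In this assay, chloro in place of methyl gives a 17-fold lower number from compound 2 to compound 4 (1.22 log units; beyond the scatter), while chloro in place of nitro gives only a 2.1-fold higher number from compound 1 to compound 4 (0.33 log units; beyond the scatter), so among these three groups on an otherwise identical aryl group, chloro stays much closer to nitro than to methyl. The whole-group exchange gives a 4.7-fold lower number from compound 3 to compound 4 (0.67 log units; beyond the scatter), but it alters two ring substituents at once, so their shares cannot be separated. Nothing available explains the order of these groups.

Still open, as far as these compounds go, is whether a bromo, an amine or a nitrile in the place of the chloro would match the nitro of compound 1. Also open, from the compounds shown here alone, is what the methoxy group of compound 4 contributes.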